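Swapping 2-fluorobenzyl for 4-nitrobenzyl at a reporting limit

This account rests on a few compounds, and the source may have more. Where it says the series, first, only, none or still open, it means among the compounds named here.

Among the compounds with values here, only two compounds have results so far in a physicochemical assay for lipophilicity, at pH 7.4 (a lower number here means a more polar compound, a higher number a more lipophilic compound), and neither result is a number. Compound 1 `Cc1cc(NC(=O)NCCCC[C@@H](Nc2cc(C)c(F)c(C)c2)C(=O)NO)ccc1F` gives < 3 as a limit of the assay. Compound 2 `Cc1cc(N[C@H](CCCCNCc2ccccc2F)C(=O)NO)cc(C)c1F` gives < 3 as a limit as well, so no exact figure places it. Within the data shown here, the data amount to the limit of < 3 in this assay, at which 2 of the 2 values shown sit, and offer no measured step from which to scale a change.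

Compound 3 `Cc1cc(N[C@H](CCCCNCc2ccc([N+](=O)[O-])cc2)C(=O)NO)cc(C)c1F` follows from compound 2 with 4-nitrophenyl in place of 2-fluorophenyl on a saturated chain carbon bound to an amine nitrogen. The same difference, cut one bond further out, reads 2-fluorobenzyl to 4-nitrobenzyl.

No shift beyond the usual scatter is expected, and no direction can be argued, so the expected step that the limit leaves unreadable from compound 2 to compound 3 in this assay stays small. This expectation rests on compound 2, whose result of < 3 is itself only a limit. Compound 3 is estimated at 2.4 in this assay, with an expected range from 1.5 to 3.1 and a strong chance of another limit.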

Compound 3, distribution coefficient: < 3
Compound 3 was reported as a limit (the forecaster's own chance of this, stated with the estimate: 80%); the middle value does not contradict the limit.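

No step can be read from compound 2 to compound 3, because the results for both in this assay are limits and not numbers: the limit of < 3 in this assay, at which 3 of the 3 values shown sit.

The compounds shown leave open where any of them truly lies relative to that limit, and whether 4-nitrobenzyl in place of 2-fluorobenzyl shifts the distribution coefficient at all.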